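The source may hold more compounds than are shown below. What is called first, only, known or untested is meant among the compounds shown, and "the series" means these compounds.

Measured so far:
compound 1 `Nc1ncc(-c2nc3ccccc3s2)c(N[C@@H]2C[C@H](CO)[C@@H](O)[C@H]2O)n1`: > 25000 nM
compound 2 `Cc1nc(NC(C)(C)C)nc(N[C@@H]2C[C@H](CO)[C@@H](O)[C@H]2O)c1-c1nc2ccccc2s1`: 12000 nM

In an ADME assay on cells (Homo sapiens) for cytotoxicity, read by polymerase chain reaction, with a stated time of 3 days (on this read-out lower numbers stand for higher toxicity in this test and higher numbers for lower toxicity in this test), compound 1 gives > 25000 nM, a limit of the assay rather than a number. Compound 1 thus sits at the limit of > 25000 nM in this assay, at which 1 of the 2 values shown sits. Among the compounds with values here, compound 2 gives 12000 nM in this assay, the only number among the values shown. Compound 3 `Cc1nc(NCc2cccnc2)nc(N[C@@H]2C[C@H](CO)[C@@H](O)[C@H]2O)c1-c1nc2ccccc2s1` differs from compound 2 in one place: (pyridin-3-yl)methyl in place of tert-butyl on a nitrogen on an aromatic ring. No measured step between two of these compounds exists to guide the expectation, so the step of no change at the digits printed from compound 2 to compound 3 (within the scatter) is expected to stay within the usual scatter. Compound 3 is estimated at 12000 nM, with a range from 5000 nM to 30000 nM.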

Compound 3, half-maximal cytotoxic concentration: 5000 nM
The estimate for compound 3 lay 2.4-fold (0.38 log units) above the measured number; the range from low to high includes it.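

The group on a nitrogen on an aromatic ring matters to this read-out: in this assay, putting (pyridin-3-yl)methyl in place of tert-butyl gives a 2.4-fold lower number from compound 2 to compound 3 (0.38 log units; beyond the scatter), which means higher toxicity in this test. Within the data shown here, this is the first change in one place that can be read, and it is a single step. Nothing measured here accounts for it.

The compounds shown leave open whether the ring as such or its nitrogen goes with this shift. A benzyl group on the same nitrogen would separate the two.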